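Trading a methoxy for a hydroxy on a shared urea core

The source may report more compounds than this note shows. Statements on the series, on what has been measured and on what is new or still open speak of the compounds shown alone.

Measured compounds:
- compound 1, `O=C(Nc1cccc(-n2cc(-c3ccncc3)c(-c3ccc(Cl)c(O)c3)n2)c1)Nc1cccc(C(F)(F)F)c1`: 4970 nM
- compound 2, `O=C(Nc1cccc(-n2cc(-c3ccncc3)c(-c3ccc(Cl)c(O)c3)n2)c1)Nc1ccc(Cl)c(Cl)c1`: 1200 nM
- compound 3, `COc1cc(-c2nn(-c3cccc(NC(=O)Nc4ccc(Cl)c(C(F)(F)F)c4)c3)cc2-c2ccncc2)ccc1Cl`: 1450 nM

All three were tested in a functional assay on SK-OV-3 cells (Homo sapiens) for inhibition, read by sulforhodamine B assay, with a stated time of 48 h; a higher number here means a weaker inhibitor of growth, a lower number a stronger inhibitor of growth. Compound 3 sits second highest of the three numbers: compound 2 lies close, within the scatter, while compound 1 stands a clear step higher. Going by the values given here, the one measured step, a 4.1-fold lower number from compound 1 to compound 2 (0.62 log units; beyond the scatter), concerns the aryl group on the urea nitrogen and is modest.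

Compound 4, `O=C(Nc1cccc(-n2cc(-c3ccncc3)c(-c3ccc(Cl)c(O)c3)n2)c1)Nc1ccc(Cl)c(C(F)(F)F)c1`, is not yet measured. It differs from compound 3 by hydrogen in place of methyl on an oxygen on an aromatic ring. Among the compounds with values here, no measured pair shows this change on its own, so no step bears on it directly. What the data do show is that compounds 1 and 2, both carrying the hydroxy, bracket a range in this assay, and compound 4 carries an aryl group related to both of theirs. With nothing pointing either way, the expected step from compound 3 is small, likely within the scatter. Compound 4 is therefore estimated at about 1500 nM, with a range from 600 nM to 4000 nM. The expected change is a 1.0-fold higher number from compound 3 to compound 4 (0.01 log units; within the scatter).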

Compound 4, concentration for 50% growth inhibition: 1340 nM
Compound 4: middle estimate off by 1.1-fold (0.05 log units), on the high side; the measured number falls inside the stated range.
By their numbers in this assay, from the lowest: compounds 2, 4 and 3 (each within the scatter of the next); then compound 1.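

In this assay, going from methoxy to hydroxy on the 4-chloro-3-methoxyphenyl group gives a 1.1-fold lower number from compound 3 to compound 4 (0.03 log units; within the scatter), so this pair does not separate hydrogen from methyl on this oxygen. Compound 4 also adds two comparisons on the aryl group of the urea with the hydroxy held constant: trifluoromethyl in place of chloro on an aromatic carbon gives a 1.1-fold higher number from compound 2 to compound 4 (0.05 log units; within the scatter), while chloro in place of hydrogen on an aromatic carbon gives a 3.7-fold lower number from compound 1 to compound 4 (0.57 log units; beyond the scatter), so among these compounds only the added chloro produces a step beyond the scatter. No supporting measurement is available to explain any of these results.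

Methoxy and hydroxy are compared here with only one aryl group on the urea, so it remains open whether they would also match with the 3,4-dichlorophenyl or 3-(trifluoromethyl)phenyl group. As far as these compounds go, it is also open whether an ethoxy group, a longer chain on this oxygen or an amine in place of the hydroxy would leave the growth-inhibition number in the same region.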